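Swapping the chloromethyl arm for a sulfoxide-bearing alkene

This account rests on a few compounds, and the source may have more. Where it says the series, first, only, none or still open, it means among the compounds named here.

Of the compounds shown here, three sharing one core have been measured in an assay for inhibition of Fatty-acid amide hydrolase 1 (Rattus norvegicus), using a Dixon plot; a lower number here means a stronger inhibitor, a higher number a weaker inhibitor. Compound 1 `COC(=O)c1ccc(-c2cnc(C(=O)CCCCCCc3ccccc3)o2)nc1` gives 3.1 nM. Compound 2 `COCOCc1ccc(-c2cnc(C(=O)CCCCCCc3ccccc3)o2)nc1` gives 10.1 nM. Compound 3 `O=C(CCCCCCc1ccccc1)c1ncc(-c2ccc(CCl)cn2)o1` gives 22.4 nM, the highest of the three numbers, with compound 2 nearest and compound 1 furthest away.

The next compound, compound 4 `C[S+]([O-])/C=C/c1ccc(-c2cnc(C(=O)CCCCCCc3ccccc3)o2)nc1`, differs from compound 3 in one place: a group of 5 heavy atoms (3 carbon, 1 oxygen, 1 sulfur; no ring) in place of a group of 2 heavy atoms (1 carbon, 1 chlorine; no ring), on an aromatic carbon. The measured steps that bear on this position are a 7.2-fold higher number from compound 1 to compound 3 (0.86 log units; beyond the scatter) and a 2.2-fold higher number from compound 2 to compound 3 (0.35 log units; beyond the scatter), and both show that exchanging the group on this aromatic carbon moves the number by a modest amount across the three measured compounds. Both of the groups that gave lower numbers than the chloromethyl carry an oxygen acceptor, as the entering group does. On that basis a modest step downward is expected for compound 4 in this assay, placing it between the values of compound 2 and compound 1, though the new group is unlike either and the step could be smaller. From compound 3 the expected change is a 2.8-fold lower number from compound 3 to compound 4 (0.45 log units; beyond the scatter). Compound 4 is therefore estimated at 8 nM, with a range from 2.5 nM to 25 nM.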

Compound 4, inhibition constant: 3 nM
The estimate for compound 4 lay 2.7-fold (0.43 log units) above the measured number, and the stated range covers the measured number.
By their numbers in this assay, from the lowest: compounds 4 and 1 (each within the scatter of the next); then compound 2; then compound 3.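

In this assay, the sulfoxide-bearing alkene gives a 7.5-fold lower number from compound 3 to compound 4 (0.87 log units; beyond the scatter), and a 3.4-fold lower number from compound 2 to compound 4 (0.53 log units; beyond the scatter), even though the group in compound 2 at this position has the same count of heavy atoms as the new group, so that count alone does not set the number here. Within the data shown here, with a 1.0-fold lower number from compound 1 to compound 4 (0.01 log units; within the scatter), compound 4 sits level with compound 1, showing that the methoxycarbonyl of compound 1 is not the only group at this position to reach such a low number, and that a group with sulfur, a double bond and no ester can do so as well. Nothing available explains why these groups give different numbers.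

The compounds shown do not separate the contributions of the sulfoxide and the alkene, so it remains open whether a sulfone on the same alkene, or an alkene carrying no sulfur, would hold the number at this level. From the compounds shown here alone, how an amine or a carboxylic acid on this aromatic carbon would compare also remains unknown.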